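Swapping the aryl ether group on a thiazolidinedione core

The source may report more compounds than this note shows. Statements on the series, on what has been measured and on what is new or still open speak of the compounds shown alone.

Of the compounds shown here, three sharing one core have been tested in a functional assay for agonist activity at Free fatty acid receptor 1 (Homo sapiens), read by FLIPR, in the presence of a further agent that is not named here; on this read-out higher numbers stand for an effect only at larger amounts of compound and lower numbers for an effect already at smaller amounts. Compound 1 `Cc1cccc(Oc2ccc(CC3SC(=O)NC3=O)cc2)n1` gives 2620 nM, compound 2 `O=C1NC(=O)C(Cc2ccc(Oc3ccc(Cl)cn3)cc2)S1` gives 1870 nM, and compound 3 `O=C1NC(=O)C(Cc2ccc(Oc3ccc(F)cc3)cc2)S1` gives 480 nM. Compound 3 therefore stands lowest of the three, that is, it acts at the smallest amount: the step of a 5.5-fold lower number from compound 1 to compound 3 (0.74 log units; beyond the scatter) and the step of a 3.9-fold lower number from compound 2 to compound 3 (0.59 log units; beyond the scatter) both lie beyond the scatter, whereas the step of a 1.4-fold lower number from compound 1 to compound 2 (0.15 log units; within the scatter) does not.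

Compound 4 `O=C1NC(=O)C(Cc2ccc(Oc3ccccc3Cl)cc2)S1` keeps the core of compound 3 and differs from it in one place: 2-chlorophenyl in place of 4-fluorophenyl on an oxygen on an aromatic ring. Within the data shown here, only the steps of a 5.5-fold lower number from compound 1 to compound 3 (0.74 log units; beyond the scatter) and a 3.9-fold lower number from compound 2 to compound 3 (0.59 log units; beyond the scatter) touch this same position, and both were modest; neither involves the change from fluorine to chlorine or the new placement of the halogen on the ring, so there is no direct precedent. A small to moderate rise in the number is expected for compound 4 in this assay, with a 1.9-fold higher number from compound 3 to compound 4 (0.27 log units; within the scatter) the estimated step, giving an estimate of 900 nM, ranging from 300 nM to 3000 nM.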

Compound 4, half-maximal effective concentration: 1190 nM
For compound 4 the middle estimate is 1.3-fold (0.12 log units) below the measured one, and the stated range covers the measured number.
By their numbers in this assay, from the lowest: compound 3; then compounds 4, 2 and 1 (each within the scatter of the next, the first and the last beyond it).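

In this assay, exchanging one halogen-bearing phenyl group for another still moves the number, with a 2.5-fold higher number from compound 3 to compound 4 (0.39 log units; beyond the scatter) here, so a phenyl group at this position does not by itself give the low number of compound 3. Set against the pyridinyl compounds, the same 2-chlorophenyl group gives a 1.6-fold lower number from compound 2 to compound 4 (0.20 log units; within the scatter) and also a 2.2-fold lower number from compound 1 to compound 4 (0.34 log units; beyond the scatter) here, so only the second of these two swaps separates the compounds beyond the scatter. No measurement at hand explains these differences.

Compound 3 and compound 4 differ in both the halogen and its placement, so the two changes cannot be told apart; a 4-chlorophenyl or a 2-fluorophenyl group would separate them. As far as these compounds go, how a methoxy group or a carboxylic acid on this phenyl ring would read also remains open.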